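From Compound 3 to Compound 4: Ethyl Replaced by Hydrogen

The source may hold more compounds than are shown below. What is called first, only, known or untested is meant among the compounds shown, and "the series" means these compounds.

Compound 1 `CC(C)OC(=O)C(=O)Nc1cccccc1=O`: 72%
Compound 2 `O=C(O)C(=O)Nc1cccccc1=O`: 62%; 68%; 73% (3 entries)
Compound 3 `CCOC(=O)COC(=O)C(=O)Nc1cccccc1=O`: 64%

In a functional assay on the whole organism (strain Sprague-Dawley CD) for inhibition, with Rattus norvegicus as the target, read by paw edema, at a dose of 100 mg/kg by the oral route (a lower number here means a weaker effect, a higher number a stronger effect of the compound at the dose given), compound 3 gives the lowest of the two single numbers, and its nearest neighbour is compound 1, whose value sits only a little higher, a gap that lies within the scatter. Compound 2 has several entries rather than one number (the several entries of compound 2 in this assay, 62%; 68%; 73% (3 entries)), and all of them sit in the same region as compound 1 and compound 3.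

Compound 4 `O=C(O)COC(=O)C(=O)Nc1cccccc1=O` differs from compound 3 by hydrogen in place of ethyl on an oxygen next to a carbonyl group. Going by the values given here, the one measured step that bears on a change at this oxygen is a number 8 percentage points lower from compound 1 to compound 3 (within the scatter), which stayed within the scatter. Among the compounds with values here, nothing among the measured compounds shows a change on this oxygen moving the read-out beyond the usual spread, so no step beyond the scatter is expected here.

Compound 4 is therefore expected to give about 65%, within a range from 50% to 78%. The step this implies, a number 1 percentage points higher from compound 3 to compound 4 (within the scatter), is estimated to be within the scatter.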

Compound 4, a percentage reported as inhibition, in the whole organism at one dose (the size of the read-out at that dose, not a potency): 50%
The estimate for compound 4 lay 15 percentage points above the measured number; the measured number falls inside the stated range.
By their numbers in this assay, from the lowest: compound 4; then compounds 3 and 1 (each within the scatter of the next).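

In this assay, going by these compounds alone, hydrogen in place of ethyl gives the first change on this oxygen that leaves the scatter, a number 14 percentage points lower from compound 3 to compound 4 (beyond the scatter), whereas the exchange of isopropyl for (ethoxycarbonyl)methyl stayed within it. Carboxymethyl in place of isopropyl on the same oxygen gives a number 22 percentage points lower from compound 1 to compound 4 (beyond the scatter), so the outer end of this group can shift the read-out at this dose, although both steps are modest. Compound 2, which carries hydrogen here instead of carboxymethyl, does not share the low number of compound 4, as its printed values show: the several entries of compound 2 in this assay, 62%; 68%; 73% (3 entries)

The compounds shown leave open whether the lower number follows the carboxy end or its combination with this short chain. A longer chain ending in carboxy, or a primary amide or an amine at that end, would separate these readings.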